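Flipping one stereocentre in a potent fluoro compound

A few compounds are considered here, and "the series" means these few. Any claim that something is new, unique, unknown or untested is made for them only; others in the source may bear on it.

Measured in a functional assay on NCI-H460 cells (Homo sapiens) for antiproliferative activity, with a stated time of 72 h; on this read-out lower numbers stand for stronger inhibition and higher numbers for weaker inhibition:
- Compound 1 `C=CC[C@H]1C[C@]2([C@@H](C)Cc3cc(C)c(OC)cc3F)OCOC2=CC1=O`: 650 nM
- Compound 2 `C=CC[C@H]1C[C@]2([C@@H](C)Cc3cc(F)c(OC)cc3F)OCOC2=CC1=O`: 59 nM

Of the two measured compounds, compound 2 has the lower number, at 59 nM. Among the compounds with values here, the only measured step is an 11-fold lower number from compound 1 to compound 2 (1.04 log units; beyond the scatter), with fluoro in place of methyl on an aromatic carbon.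

Compound 3 `C=CC[C@H]1C[C@]2([C@H](C)Cc3cc(F)c(OC)cc3F)OCOC2=CC1=O` is a close relative of compound 2: the two compounds have the same atoms and bonds and differ only in configuration as drawn: 1 of 3 stereo elements differ; a stereocentre at a saturated chain carbon is drawn S in compound 2 and R in compound 3. A stereocentre at a saturated chain carbon is drawn S in compound 2 and R in compound 3. Within the data shown here, no measured step changes configuration, so the earlier step shows only that one small change can move this assay well beyond the scatter. Its size cannot be carried over directly. A weaker result is expected, since compound 2 starts from the better of the two numbers, but the size is uncertain. The estimated step is a 5.1-fold higher number from compound 2 to compound 3 (0.71 log units; beyond the scatter). For compound 3 the estimate is 300 nM, with an expected range of 60 nM to 2500 nM.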

Compound 3, half-maximal inhibitory concentration: 35 nM
Estimate against measurement, compound 3: 8.6-fold (0.93 log units) above, outside the stated range (below it).
By their numbers in this assay, from the lowest: compounds 3 and 2 (each within the scatter of the next); then compound 1.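

In this assay, the stereocentre at a saturated chain carbon can be drawn S or R with no change that stands out from the usual scatter: a 1.7-fold lower number from compound 2 to compound 3 (0.23 log units; within the scatter). This differs from the swap of methyl for fluoro on the aromatic carbon, which moved the number well beyond the scatter, so not every single change in this series matters on this read-out. The pair gives an unusually clean test of this one carbon, and the reading rests on a single fact: the fact that compounds 2 and 3 differ only in the configuration as drawn.

From the compounds shown here alone, whether the same indifference to configuration would hold with methyl in place of that aromatic fluoro, as in compound 1, remains open. So does what an ethyl group or a hydroxyl group on this chain carbon would do to the number.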